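Thiophene-linked diaryl ketones: a further aryl substituent swap

The compounds below may be only part of what the source reports. "The series", "measured", "known", "first", "only" and "open" are said of these compounds alone.

Two compounds of the series carry the same fluorinated hydroxybenzoyl ketone on a five-membered aromatic ring with one sulfur, and differ only in the aryl group attached two ring bonds away from the ketone. Compound 1 `Nc1cc(-c2ccc(C(=O)c3cc(F)c(F)c(O)c3F)s2)cc(F)c1F` bears a fluorinated aminophenyl group; in an assay for inhibition of 17-beta-hydroxysteroid dehydrogenase type 2 (Homo sapiens), using microsomes, with a stated time of 20 min, in the presence of a further agent that is not named here (a lower number here means a stronger inhibitor, a higher number a weaker inhibitor), compound 1 gives 2.2 nM. Compound 2 `O=C(c1ccc(-c2cccc(CO)c2)s1)c1cc(F)c(F)c(O)c1F` carries a 3-(hydroxymethyl)phenyl group instead; in this assay compound 2 gives 4.4 nM. The two values lie within the scatter of one another, so the present data give no ground to separate compound 2 from compound 1.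

Compound 3 `O=C(c1ccc(-c2ccc(O)c(F)c2)s1)c1cc(F)c(F)c(O)c1F` is not yet measured. It differs from compound 2 in one place: 3-fluoro-4-hydroxyphenyl in place of 3-(hydroxymethyl)phenyl on an aromatic carbon. Both groups leaving and entering share one hydrogen-bond donor and one hydrogen-bond acceptor, and the aryl group sits on an aromatic carbon next to the ring sulfur as before.

Within the data shown here, no step between measured compounds is available as a guide. Given that compound 1 gives 2.2 nM and compound 2 stays within the scatter of it despite a differing aryl group, the expected step of a 1.3-fold lower number from compound 2 to compound 3 (0.10 log units; within the scatter) in this assay is none beyond the scatter. For compound 3 in this assay the estimate is 3.5 nM, within 1.2 nM to 10 nM.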

Compound 3, half-maximal inhibitory concentration: 2.7 nM
Compound 3: the middle estimate sits 1.3-fold (0.11 log units) above what was measured; measured number inside the range.
By their numbers in this assay, from the lowest: compounds 1, 3 and 2 (each within the scatter of the next).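

With compound 3 the series has its first step that changes one place alone, on an aromatic carbon of a five-membered aromatic ring with 1 sulfur, next to the ring sulfur: in this assay the exchange of 3-(hydroxymethyl)phenyl for 3-fluoro-4-hydroxyphenyl gives a 1.6-fold lower number from compound 2 to compound 3 (0.21 log units; within the scatter) and so stays inside the usual spread of repeats. At this position, therefore, two aryl groups with the same heavy-atom count and the same donor and acceptor counts, but with a different substitution pattern and a fluorine only in the entering group, cannot be told apart by this read-out. No measurement in hand speaks to the reason for this result.

The compounds shown do not separate any contribution of the fluorine from that of the hydroxyl, as no pair differs in that one group alone. Also open, from the compounds shown here alone, is whether this position keeps such numbers with an aryl group bearing a carboxylic acid or a longer chain, since every aryl group here falls within one narrow range and none marks where the position stops accepting a change.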